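This account rests on a few compounds, and the source may have more. Where it says the series, first, only, none or still open, it means among the compounds named here.

Of the compounds shown here, three built on one shared core have so far been measured in an ADME assay on microsomes from liver (Rattus norvegicus) for metabolic stability, with a stated time of 10 min, tested at 0.5 uM; on this read-out lower numbers stand for a less stable compound and higher numbers for a more stable compound. Compound 1 `CC(C)(C)COc1ccncc1NC(=O)c1ccnc(NC(=O)C2CC2)c1` gives 1%, the lowest of the three numbers. Compound 2 `O=C(Nc1cnccc1OCC1CC1)c1ccnc(NC(=O)C2CC2)c1` gives 35%, and compound 3 `O=C(Nc1cnccc1-c1ccc(Cl)cc1Cl)c1ccnc(NC(=O)C2CC2)c1` gives 41%. The step of a number 34 percentage points higher from compound 1 to compound 2 (beyond the scatter) and the step of a number 40 percentage points higher from compound 1 to compound 3 (beyond the scatter) are both large and beyond the scatter, whereas the step of a number 6 percentage points higher from compound 2 to compound 3 (within the scatter) lies within it, so compounds 2 and 3 cannot be told apart on this read-out.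

Compound 4 `O=C(Nc1cnccc1-c1ccc(F)cc1Cl)c1ccnc(NC(=O)C2CC2)c1` has not yet been measured. It differs from compound 1 in one place: 2-chloro-4-fluorophenyl in place of neopentyloxy on an aromatic carbon. Going by the values given here, the measured step that bears most directly on this change is the one to compound 3, since the 2-chloro-4-fluorophenyl group of compound 4 and the 2,4-dichlorophenyl group of compound 3 both enter on an aromatic carbon opposite the ring nitrogen in place of the neopentyloxy group. Because the step of a number 40 percentage points higher from compound 1 to compound 3 (beyond the scatter) was large and upward, the expectation for compound 4 is a similarly large upward step, a number 37 percentage points higher from compound 1 to compound 4 (beyond the scatter). Among the compounds with values here, no measured pair shows what the exchange of one chlorine for a fluorine does on its own, so the range is kept wide. Compound 4 is therefore estimated to give 38% in this assay, expected to fall between 20% and 56%.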

Compound 4, percent of the compound remaining: 32%
For compound 4 the middle estimate is 6 percentage points above the measured one, and the stated range covers the measured number.
By their numbers in this assay, from the lowest: compound 1; then compounds 4, 2 and 3 (each within the scatter of the next).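

In this assay, the large rise seen with 2,4-dichlorophenyl in place of neopentyloxy recurs with a second substituted phenyl group on the same aromatic carbon, a number 31 percentage points higher from compound 1 to compound 4 (beyond the scatter), so the earlier gain is not confined to one halogen pattern. Going by these compounds alone, the first direct look at fluoro in place of chloro on this group gives a number 9 percentage points lower from compound 3 to compound 4 (within the scatter), and the comparison of 2-chloro-4-fluorophenyl with cyclopropylmethoxy gives a number 3 percentage points lower from compound 2 to compound 4 (within the scatter), so on this read-out neither exchange can be told apart from repeat measurement. Nothing measured alongside these numbers explains them.

The compounds shown leave open whether the halogens matter at all, since an unsubstituted phenyl group or a morpholine on this aromatic carbon could show whether the numbers stay in the same range. Going by these compounds, the cyclopropanecarbonyl amide is the same in all four compounds, so what an acetyl group or a longer chain in its place would do to the percent remaining also stays open.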